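A few compounds are considered here, and "the series" means these few. Any claim that something is new, unique, unknown or untested is made for them only; others in the source may bear on it.

Of the compounds shown here, two have been measured in a functional assay on V79 cells (Cricetulus griseus) for cytotoxicity, read by colony formation; a higher number here means a weaker inhibitor, a lower number a stronger inhibitor. In this assay, compound 1 `CC1(CN)CCN(c2c(F)cc3c(=O)c(C(=O)O)cn(C4CC4)c3c2F)C1` gives 8 ug/mL, a true number. Compound 2 `NC1CCCN(c2cc3c(cc2F)c(=O)c(C(=O)O)cn3C2CC2)C1` gives > 500 ug/mL, which is a limit of the assay and not a number. Compound 2 therefore has no exact position on the scale, and any step from it can only be judged against that limit.

Compound 3 `NC1CCCN(c2c(F)cc3c(=O)c(C(=O)O)cn(C4CC4)c3c2F)C1` is compound 2 with one change: fluoro in place of hydrogen on an aromatic carbon, ortho to the 3-aminopiperidin-1-yl group (fluoro in place of hydrogen on an aromatic carbon). Among the measured compounds shown here, no measured pair isolates this change, so the expectation rests on thin ground. Compound 1 carries the same fluoro group and reads 8 ug/mL, although it also differs from compound 3 elsewhere. A sizeable step in this assay is therefore expected, towards a lower number and a stronger inhibitor, with some chance that compound 3 also reads only as a limit. The expected change is an at least 8.3-fold lower number from compound 2 to compound 3 (0.92 log units; beyond the scatter). Compound 3 is estimated at 60 ug/mL, with an expected range of 12 ug/mL to 300 ug/mL.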

Compound 3, half-maximal inhibitory concentration: 53 ug/mL
For compound 3 the middle estimate is 1.1-fold (0.05 log units) above the measured one, within the range that was stated.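

In this assay, fluoro in place of hydrogen on the aromatic carbon ortho to the 3-aminopiperidin-1-yl group now has a measured pair behind it, and the change brings an at least 9.4-fold lower number from compound 2 to compound 3 (0.97 log units; beyond the scatter), so the reading clearly responds to what sits at this position. From the compounds shown here alone, the true size of that step stays unknown, because compound 2 stands at a limit of the assay and not at a number: the limit of > 500 ug/mL in this assay, at which 1 of the 3 values shown sits. With the fluoro group in place on both sides, the other substituent also matters: 3-aminopiperidin-1-yl in place of 3-(aminomethyl)-3-methylpyrrolidin-1-yl gives a 6.6-fold higher number from compound 1 to compound 3 (0.82 log units; beyond the scatter), so the fluoro group alone does not set the reading.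

The compounds shown leave open whether the fluoro step carries over to the 3-(aminomethyl)-3-methylpyrrolidin-1-yl group, as no compound shown pairs with compound 1 at this aromatic carbon. They also leave open what a chloro or a methoxy group on this carbon would do in this assay.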